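Urea and amide analogues: chloro addition on the trifluoromethylphenyl ring

The compounds below may be only part of what the source reports. "The series", "measured", "known", "first", "only" and "open" are said of these compounds alone.

Measured compounds:
compound 1 `Nc1nccc2c1ccn2-c1ccc(NC(=O)Nc2cccc(C(F)(F)F)c2)cc1`: 5400 nM
compound 2 `Nc1nccc2c1ccn2-c1ccc(NC(=O)Nc2ccc(Cl)c(C(F)(F)F)c2)cc1`: 8000 nM
compound 3 `Cc1cc(NC(=O)c2cccc(C(F)(F)F)c2)ccc1-n1ccc2c(NC(=O)c3ccccc3)nccc21`: a limit, > 10000 nM

In a functional assay on A-375 cells (Homo sapiens) for antiproliferative activity, read by MTT assay, with a stated time of 48 h, in the presence of a further agent that is not named here (a higher number here means a weaker inhibitor, a lower number a stronger inhibitor), compound 1 gives 5400 nM and compound 2 gives 8000 nM. The change between them, (chloro in place of hydrogen on an aromatic carbon), gave a 1.5-fold higher number from compound 1 to compound 2 (0.17 log units; within the scatter). For compound 3 the reading in this assay is a limit of the assay, > 10000 nM. The difference between the core of compound 1 and the core of compound 3 is not broken down here.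

Compound 4 `Cc1cc(NC(=O)c2ccc(Cl)c(C(F)(F)F)c2)ccc1-n1ccc2c(NC(=O)c3ccccc3)nccc21` has not yet been measured. It carries the same change relative to compound 3 as compound 2 does relative to compound 1: chloro in place of hydrogen on an aromatic carbon. The expected step is a step that the limit leaves unreadable from compound 3 to compound 4, resting on the step of a 1.5-fold higher number from compound 1 to compound 2 (0.17 log units; within the scatter) and on compound 3 sitting at the limit (the limit of > 10000 nM in this assay, at which 1 of the 3 values shown sits). Compound 4 is expected to give 15000 nM in this assay, most likely again only a limit.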

Compound 4, half-maximal inhibitory concentration: 2700 nM
Compound 4: middle estimate off by 5.6-fold (0.74 log units), on the high side; measured number outside the range, below it.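

In this assay, the chloro change gives an at least 3.7-fold lower number from compound 3 to compound 4 (0.56 log units; beyond the scatter), so its effect does not carry over unchanged from the core of compound 1 to the core of compound 3: the same change on two cores in this assay, a 1.5-fold higher number (0.17 log units; within the scatter) from compound 1 to compound 2 and an at least 3.7-fold lower number (0.56 log units; beyond the scatter) from compound 3 to compound 4, at least 5.4-fold (0.73 log units) apart, beyond the scatter of two such steps

Compound 3 stands at a limit, so the step on its core is a bound and not an exact size: the limit of > 10000 nM in this assay, at which 1 of the 4 values shown sits.

The two cores differ in more than one place, and these compounds do not show which difference goes with the different outcome, so one pair on each core gives no general rule for the series.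

Open, going by these compounds, is whether fluoro, bromo or a nitrile in place of the chloro would show the same split between the two cores. Also open, on these data alone, is whether the split follows the urea or amide link, the methyl group or the benzoyl amide.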